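The compounds below may be only part of what the source reports. "The series", "measured", "known", "first", "only" and "open" are said of these compounds alone.

Measured so far in an ADME assay on Vero cells (Chlorocebus sabaeus) for cytotoxicity, read by MTT assay, with a stated time of 72 h; a higher number here means a weaker inhibitor, a lower number a stronger inhibitor:
compound 1 `[O-][S+](CCCCN=C=S)Cc1ccccc1` gives 4850 nM
compound 2 `[O-][S+](CCCCCN=C=S)Cc1ccccc1` gives 5850 nM
compound 3 `CC(C)[S+]([O-])CCCCCN=C=S` gives 10300 nM

Compound 2 differs from compound 1 by a group of 4 heavy atoms (2 carbon, 1 nitrogen, 1 sulfur; no ring) in place of a group of 3 heavy atoms (1 carbon, 1 nitrogen, 1 sulfur; no ring), on a saturated chain carbon, four bonds along the chain from a sulfur. That change gave a 1.2-fold higher number from compound 1 to compound 2 (0.08 log units; within the scatter). Compound 4 `CC(C)[S+]([O-])CCCCCCN=C=S` has not yet been measured; relative to compound 3 it carries a group of 4 heavy atoms (2 carbon, 1 nitrogen, 1 sulfur; no ring) in place of a group of 3 heavy atoms (1 carbon, 1 nitrogen, 1 sulfur; no ring), on a saturated chain carbon, five bonds along the chain from a sulfur. The place is not the same word for word: in the earlier pair the group sits four bonds along the chain from a sulfur, here five bonds along the chain from a sulfur, so this is the same kind of change rather than the same change. How the core of compound 3 differs from the core of compound 1 is not broken down here. Beside the earlier step, the step from compound 3 to compound 4 in this assay is expected to be about a 1.2-fold higher number from compound 3 to compound 4 (0.07 log units; within the scatter) because a 1.2-fold higher number from compound 1 to compound 2 (0.08 log units; within the scatter) stayed within the scatter. Compound 4 is therefore estimated at 12000 nM, with a likely range from 6500 nM to 23000 nM.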

Compound 4, half-maximal inhibitory concentration: 7310 nM
For compound 4 the middle estimate is 1.6-fold (0.22 log units) above the measured one; low and high end bracket the measured number.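

In this assay, the chain change gave a 1.4-fold lower number from compound 3 to compound 4 (0.15 log units; within the scatter). Set beside the earlier step, the same change behaves no differently on the two cores: the same change on two cores in this assay, a 1.2-fold higher number (0.08 log units; within the scatter) from compound 1 to compound 2 and a 1.4-fold lower number (0.15 log units; within the scatter) from compound 3 to compound 4, 1.7-fold (0.23 log units) apart, within the scatter of two such steps This suggests that, for these two pairs, the change can be carried from one core to the other with little effect on the number, but it does not show that the same would hold on any other core or at any other chain length, and the opposite directions of the two steps cannot be read as a real difference.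

The compounds shown leave open whether a longer chain than that of compound 4 would stay within the scatter. They also leave open what an amine in place of the isothiocyanate would do.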